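From a Carbonate-Bearing Ester to an Isopropyl Ester

The source may report more compounds than this note shows. Statements on the series, on what has been measured and on what is new or still open speak of the compounds shown alone.

Of the compounds shown here, three have been measured in a physicochemical assay for metabolic stability, read by LC-MS, in phosphate buffer, with a stated time of 3 h, at pH 7.4, tested at 50 uM (on this read-out higher numbers stand for a more stable compound and lower numbers for a less stable compound), and every value obtained so far is a limit of the assay rather than a number.

Compound 1, `C[C@@H](O)[C@H]1C(=O)N2C(C(=O)OCOC(=O)C(C)(C)C)=C(S[C@@H]3CN[C@H](C(=O)Nc4cccc(C(=O)O)c4)C3)[C@H](C)[C@H]12`, gives > 95%.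
Compound 2, `C[C@@H](O)[C@H]1C(=O)N2C(C(=O)OCOC(=O)OC(C)(C)C)=C(S[C@@H]3CN[C@H](C(=O)Nc4cccc(C(=O)O)c4)C3)[C@H](C)[C@H]12`, gives > 95%.
Compound 3, `C[C@@H](O)[C@H]1C(=O)N2C(C(=O)OCOC(=O)OC3CCCCC3)=C(S[C@@H]3CN[C@H](C(=O)Nc4cccc(C(=O)O)c4)C3)[C@H](C)[C@H]12`, gives > 95%.

Compound 3 therefore stands at a limit of this assay, and the other two values are limits as well, all three sitting at the same point (the limit of > 95% in this assay, at which 3 of the 3 values shown sit). For this reason the steps between the measured compounds cannot be sized: a step that the two limits leave unreadable from compound 1 to compound 2, a step that the two limits leave unreadable from compound 1 to compound 3 and a step that the two limits leave unreadable from compound 2 to compound 3.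

Compound 4, `CC(C)OC(=O)C1=C(S[C@@H]2CN[C@H](C(=O)Nc3cccc(C(=O)O)c3)C2)[C@H](C)[C@@H]2[C@@H]([C@@H](C)O)C(=O)N12`, has not yet been measured. It differs from compound 3 as follows: isopropyl in place of ((cyclohexyloxycarbonyl)oxy)methyl on an oxygen next to a carbonyl group. Among the measured compounds shown here, none of the measured steps gives a readable size, so they offer no direction for this change; they do show that three compounds sharing the same core all reached the limit. The expectation for compound 4 in this assay is therefore a value at or near that limit, with no step beyond the scatter, that is a step that the limit leaves unreadable from compound 3 to compound 4. Compound 4 is estimated at 96%, with a range from 88% to 100%.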

Compound 4, percent of the compound remaining: > 95%
Compound 4: no number, only a limit; the forecaster's own chance of this, stated with the estimate: 75%; the middle value lies beyond the limit too.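

In this assay compound 4 gives > 95% as a limit of the assay, not a number. No step from compound 1, compound 2 or compound 3 to compound 4 can be read, and all four compounds sit at one point: the limit of > 95% in this assay, at which 4 of the 4 values shown sit.

The compounds shown leave open how far these four compounds differ in this assay and whether they differ at all.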